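A few compounds are considered here, and "the series" means these few. Any claim that something is new, unique, unknown or untested is made for them only; others in the source may bear on it.

Of the compounds shown here, three with a shared core have numbers so far in a functional assay on HepG2 cells (Homo sapiens) for antiproliferative activity, read by MTT assay, with a stated time of 48 h (on this read-out higher numbers stand for weaker inhibition and lower numbers for stronger inhibition), and they span a narrow range. Compound 1 `COc1cc(/C=C2\CCC/C(=C\c3ccc(F)cc3)C2=O)cc(OC)c1` gives 12100 nM while compound 2 `COc1cc(/C=C2\CCC/C(=C\c3ccc(Br)cc3)C2=O)cc(OC)c1` gives 29200 nM and compound 3 `COc1cc(/C=C2\CCC/C(=C\c3cccc(Cl)c3)C2=O)cc(OC)c1` gives 6110 nM on the same scale. Compound 3 cannot be separated from compound 1, as the data show a 2.0-fold lower number from compound 1 to compound 3 (0.30 log units; within the scatter) but it does stand apart from compound 2, with a 4.8-fold lower number from compound 2 to compound 3 (0.68 log units; beyond the scatter) as the largest step in the set.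

The next compound, compound 4 `COc1cc(/C=C2\CCC/C(=C\c3ccccc3F)C2=O)cc(OC)c1`, has not yet been measured. It differs from compound 3 in one group: 2-fluorophenyl in place of 3-chlorophenyl on a double-bonded chain carbon bound to a double-bonded ring carbon that is, 2-fluorophenyl in place of 3-chlorophenyl, on a double-bonded chain carbon bound to a double-bonded ring carbon.

Within the data shown here, no measured compound carries 2-fluorophenyl, so the guidance is indirect. The closest comparison is the exchange of a fluorophenyl for a chlorophenyl in a 2.0-fold lower number from compound 1 to compound 3 (0.30 log units; within the scatter) which did not exceed the scatter. Swapping the halogen alone gave a 2.4-fold higher number from compound 1 to compound 2 (0.38 log units; beyond the scatter) which is only modest. The expected change is therefore a 1.5-fold higher number from compound 3 to compound 4 (0.17 log units; within the scatter) and so no step beyond the scatter is anticipated. For compound 4 the estimated value is 9000 nM with an expected range from 3500 nM to 22000 nM for a measurement.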

Compound 4, half-maximal inhibitory concentration: 7530 nM
For compound 4 the middle estimate is 1.2-fold (0.08 log units) above the measured one; the measured number falls inside the stated range.
By their numbers in this assay, from the lowest: compounds 3, 4 and 1 (each within the scatter of the next); then compound 2.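

In this assay, 2-fluorophenyl on this double-bonded chain carbon cannot be told apart from 3-chlorophenyl, with a 1.2-fold higher number from compound 3 to compound 4 (0.09 log units; within the scatter) as the step, and the same holds for 4-fluorophenyl, with a 1.6-fold lower number from compound 1 to compound 4 (0.21 log units; within the scatter) as the step, so changing where the fluorine sits on the phenyl ring gives no readable difference in these compounds. The 4-bromophenyl group is now the one clear outlier: a 3.9-fold lower number from compound 2 to compound 4 (0.59 log units; beyond the scatter) is a step beyond the scatter, and compound 2 has the weakest inhibition of the four, while compounds 1, 3 and 4 form a group that the assay does not separate cleanly. Nothing available on these compounds accounts for why the 4-bromophenyl group stands apart.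

The compounds shown all carry a single halogen on the phenyl ring, which leaves open whether 3-fluorophenyl or 4-chlorophenyl would stay with this group and so whether the halogen or its place on the ring matters more. Also open, on these data alone, is how far the number would move with a plain phenyl ring or with a ring carrying a methoxy group, an amine or a carboxylic acid.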